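Swapping 3-methylphenyl for 1,3-thiazol-2-yl on the sulfonyl sulfur

This account rests on a few compounds, and the source may have more. Where it says the series, first, only, none or still open, it means among the compounds named here.

Compound 3 `Cc1cccc(S(=O)(=O)c2ccc(NC(=O)C(C)(O)C(F)(F)F)cc2)c1` gives 2200 nM in a functional assay (Cavia porcellus) with sulfonylurea receptors; K-ATP channels (Homo sapiens) as the target (on this read-out lower numbers stand for stronger inhibition and higher numbers for weaker inhibition), the second highest of the three numbers measured. Compound 1 `CC(O)(C(=O)Nc1ccc(S(=O)(=O)c2ccccc2F)cc1)C(F)(F)F` gives 1300 nM in this assay, and a 1.7-fold higher number from compound 1 to compound 3 (0.23 log units; within the scatter). Compound 2 `Cc1ccccc1S(=O)(=O)c1ccc(NC(=O)C(C)(O)C(F)(F)F)cc1` gives 5100 nM in this assay, and a 2.3-fold lower number from compound 2 to compound 3 (0.37 log units; beyond the scatter). Compound 4 `CC(O)(C(=O)Nc1ccc(S(=O)(=O)c2nccs2)cc1)C(F)(F)F` differs from compound 3 in one place: 1,3-thiazol-2-yl in place of 3-methylphenyl on a sulfonyl sulfur. Among the measured compounds shown here, of the measured steps, only a 1.7-fold higher number from compound 1 to compound 3 (0.23 log units; within the scatter) and a 2.3-fold lower number from compound 2 to compound 3 (0.37 log units; beyond the scatter) change the group on the sulfonyl sulfur, and each is small; none of them introduces a five-membered aromatic ring with 2 hetero atoms, so the new ring has no precedent here. The expected step in this assay is therefore a 1.1-fold higher number from compound 3 to compound 4 (0.06 log units; within the scatter), with no clear direction beyond the scatter. Compound 4 is estimated at 2500 nM, in a range from 800 nM to 8000 nM.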

Compound 4, half-maximal inhibitory concentration: 1400 nM
Estimate against measurement, compound 4: 1.8-fold (0.25 log units) above; low and high end bracket the measured number.
By their numbers in this assay, from the lowest: compounds 1, 4 and 3 (each within the scatter of the next); then compound 2.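

On the sulfonyl sulfur in this assay, a five-membered aromatic ring with 2 hetero atoms proves acceptable: 1,3-thiazol-2-yl lies within the scatter of both 3-methylphenyl (a 1.6-fold lower number from compound 3 to compound 4 (0.20 log units; within the scatter)) and 2-fluorophenyl (a 1.1-fold higher number from compound 1 to compound 4 (0.03 log units; within the scatter)). Only 2-methylphenyl stands clearly apart (a 3.6-fold lower number from compound 2 to compound 4 (0.56 log units; beyond the scatter)). The compounds shown offer no measurement that explains these numbers. They leave open whether a thiophen-2-yl or pyridin-2-yl group on the sulfonyl sulfur would give a similar number, and whether a methyl or an amine on the 1,3-thiazol-2-yl ring would shift it.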